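Swapping a Nitrile for a Methylsulfonyl Group

The source may hold more compounds than are shown below. What is called first, only, known or untested is meant among the compounds shown, and "the series" means these compounds.

Compound 1 `CS(=O)(=O)c1ccc(Cn2c(=O)n(Cc3nc4ccccc4n3CCCC#N)c3ccncc32)cc1` gives 40900 nM in an ADME assay on HEp-2 cells (Homo sapiens) for cytotoxicity; on this read-out higher numbers stand for lower toxicity in this test and lower numbers for higher toxicity in this test.
Compound 2 `N#CCCCn1c(Cn2c(=O)n(Cc3ccc(C#N)cc3)c3ccncc32)nc2ccccc21` gives 36800 nM in this assay.

Compound 2 holds the lowest of the two numbers, and compound 1 sits within the scatter of it, so no order between them can be read. Compound 3 `CS(=O)(=O)c1ccc(Cn2c(=O)n(Cc3nc4ccccc4n3CCCC#N)c3cnccc32)cc1` differs from compound 2 by methylsulfonyl in place of cyano on an aromatic carbon. Among the measured compounds shown here, no measured pair shows this exact change. The step of a 1.1-fold higher number from compound 2 to compound 3 (0.04 log units; within the scatter) is expected to stay within the scatter, in no clear direction, since compound 1 carrying the same methylsulfonyl group gives 40900 nM. Compound 3 is estimated at 40000 nM, with a range from 20000 nM to 80000 nM.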

Compound 3, half-maximal cytotoxic concentration: 1980 nM
Compound 3: middle estimate off by 20-fold (1.31 log units), on the high side; measured number outside the range, below it.
By their numbers in this assay, from the lowest: compound 3; then compounds 2 and 1 (each within the scatter of the next).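

At this place on the benzyl ring, methylsulfonyl in place of cyano is not a neutral swap in this assay: it brings a 19-fold lower number from compound 2 to compound 3 (1.27 log units; beyond the scatter). The group alone does not set the number, since compound 1 carries the same 4-(methylsulfonyl)benzyl group, with the ring nitrogen of the core placed differently, and gives 40900 nM. No measurement shown here accounts for the drop. Still open, as far as these compounds go, is whether a cyano group on the core of compound 3 would give a similarly low number, and how an amine or a carboxylic acid at this place would read.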